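From ethyl to isopropyl: an estimate for compound 3

The compounds below may be only part of what the source reports. "The series", "measured", "known", "first", "only" and "open" are said of these compounds alone.

- compound 1 `c1cnc2c(c1)CCC[C@@H]2N(CC1CC1)C[C@H]1Cc2c(cccc2N2CCNCC2)CN1` gives 88.3% as measured
- compound 2 `CCN(C[C@H]1Cc2c(cccc2N2CCNCC2)CN1)[C@H]1CCCc2cccnc21` gives 53.8% as measured

In an ADME assay on microsomes from liver (Mus musculus) for metabolic stability, read by LC-MS, with a stated time of 10 min (on this read-out lower numbers stand for a less stable compound and higher numbers for a more stable compound), compound 2 gives 53.8% as the lower of the two numbers, and compound 1 stands higher, beyond the scatter. Compound 3 `CC(C)N(C[C@H]1Cc2c(cccc2N2CCNCC2)CN1)[C@H]1CCCc2cccnc21` differs from compound 2 by methyl in place of hydrogen on a saturated chain carbon bound to an amine nitrogen and a saturated chain carbon and this is methyl in place of hydrogen on a saturated chain carbon bound to an amine nitrogen and a saturated chain carbon, or ethyl to isopropyl.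

Within the data shown here, one measured step bears on this change. Methyl in place of cyclopropyl on a saturated chain carbon bound to an amine nitrogen gave a number 34.5 percentage points lower from compound 1 to compound 2 (beyond the scatter) as the only guide. Among the measured compounds shown here, compound 3 carries no cyclopropyl, so a rise smaller than that step is expected, and no isopropyl compound has been measured yet. Expected is a number 14.2 percentage points higher from compound 2 to compound 3 (beyond the scatter) in this assay with the direction more secure than the size. For compound 3 the estimated value is 68% with an expected range from 50% to 86% on this read-out.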

Compound 3, percent of the compound remaining: 91%
Estimate against measurement, compound 3: 23 percentage points below, and the stated range ends below it.
By their numbers in this assay, from the lowest: compound 2; then compounds 1 and 3 (each within the scatter of the next).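

In this assay, methyl in place of hydrogen on a saturated chain carbon bound to an amine nitrogen and a saturated chain carbon gives a number 37.2 percentage points higher from compound 2 to compound 3 (beyond the scatter), so a single added methyl at this place is enough for a large change, whereas the earlier pair showed a large change only with cyclopropyl in the group. Isopropyl in place of cyclopropylmethyl on an amine nitrogen gives a number 2.7 percentage points higher from compound 1 to compound 3 (within the scatter), so these two groups cannot be told apart on this read-out, and among the compounds shown, the cyclopropyl ring is not required for a number at this level, with ethyl in compound 2 the only group that stands apart. Nothing available explains either step.

Still open, on these data alone, is whether a straight propyl chain or a tert-butyl group on the same amine nitrogen would read with compound 2 or with compound 1 and compound 3, which would show whether chain length or branching tracks with the read-out. A cyclobutyl group or a methoxyethyl chain on that nitrogen would test how far the tolerated groups extend beyond the plain hydrocarbons shown.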